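A few compounds are considered here, and "the series" means these few. Any claim that something is new, unique, unknown or untested is made for them only; others in the source may bear on it.

Measured compounds:
Compound 1, `COc1ccc(/C=C/C2(C)C=CC(=O)O2)c(OC)c1OC`, in a functional assay on K562 cells (Homo sapiens) for inhibition, read by sulforhodamine B assay, with a stated time of 48 h (on this read-out higher numbers stand for weaker inhibition of growth and lower numbers for stronger inhibition of growth), gives only a limit, > 1000000 nM.
Compound 2, `COc1c(O)ccc(/C=C/C2(C)C=CC(=O)O2)c1OC`, in this assay gives only a limit, > 1000000 nM.
Compound 3, `CC1(/C=C/c2cccc(O)c2)C=CC(=O)O1`, in this assay gives only a limit, > 1000000 nM.

All three values sit at the same limit, (the limit of > 1000000 nM in this assay, at which 3 of the 3 values shown sit). From compound 2 to compound 1 the change is methyl in place of hydrogen on an oxygen on an aromatic ring; the two limits leave the size of that step unreadable, a step that the two limits leave unreadable from compound 2 to compound 1.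

Compound 4, `COc1cccc(/C=C/C2(C)C=CC(=O)O2)c1`, is not yet measured. It differs from compound 3 by methyl in place of hydrogen on an oxygen on an aromatic ring, the same change as from compound 2 to compound 1, at a place described in the same words. The difference between the core of compound 3 and the core of compound 2 is not broken down here.

With the earlier step unreadable and all three measured values at the limit, the expected step is a number no higher from compound 3 to compound 4 (the limit leaves the size open), essentially no change. In this assay compound 4 is therefore estimated at 1000000 nM, most likely again reported only as a limit.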

Compound 4, concentration for total growth inhibition: > 1000000 nM
Compound 4 gave a limit, no number; the forecaster's own chance of this, stated with the estimate: 85%; the middle value sits exactly at the limit.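

In this assay compound 4 gives only a limit, > 1000000 nM, and no step from compound 3 to compound 4 can be read: the limit of > 1000000 nM in this assay, at which 4 of the 4 values shown sit.

The compounds shown leave open whether hydroxy to methoxy changes growth inhibition at all, and how strongly any of them inhibits growth.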